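The compounds below may be only part of what the source reports. "The series", "measured", "known", "first", "only" and "open" are said of these compounds alone.

Measured compounds so far:

compound 1, `CC(=O)N1CCN(Cc2nc3ccccc3n2Cc2cccc(C)c2)CC1`: in an assay on isolated protein for inhibition of aldehyde dehydrogenase 1A1 (Homo sapiens), read by spectrophotometry, tested at 10 uM (on this read-out higher numbers stand for more inhibition at the one concentration tested (going by the name of the read-out) and lower numbers for less inhibition), compound 1 gives 70.3%

compound 2, `Cc1cccc(Cn2c(CN3CCN(C(=O)c4ccc(C#N)cc4)CC3)nc3ccccc32)c1`: in this assay compound 2 gives 20.8%

Among these two numbers compound 2 holds the lower one, and the gap to compound 1 lies beyond the usual scatter of this measurement. Among the compounds with values here, the single measured step, a number 49.5 percentage points lower from compound 1 to compound 2 (beyond the scatter), came with 4-cyanophenyl in place of methyl on a carbonyl carbon.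

Compound 3, `Cc1cccc(Cn2c(CN3CCN(C(=O)c4ccc(Cl)cc4)CC3)nc3ccccc32)c1`, differs from compound 2 in one place: chloro in place of cyano on an aromatic carbon. Within the data shown here, no measured step involves a change of this kind, so the one known step gives no direct guidance; it concerns a different part of the molecule. The expectation for compound 3 therefore rests on compound 2 alone, together with the observation that swapping one small group for another on the same aromatic carbon leaves most of the structure unchanged. The step expected here, a number 6.2 percentage points higher from compound 2 to compound 3 (within the scatter), is modest and may not exceed the scatter. Compound 3 is thus estimated at 27%, within a range from 8% to 50%.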

Compound 3, a percentage reported as inhibition, at one concentration (the size of the read-out at that concentration, not a potency): 23.2%
The estimate for compound 3 lay 3.8 percentage points above the measured number; the range from low to high includes it.
By their numbers in this assay, from the lowest: compounds 2 and 3 (each within the scatter of the next); then compound 1.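

In this assay, chloro in place of cyano on an aromatic carbon, para to a large group, gives a step that lies within the scatter (a number 2.4 percentage points higher from compound 2 to compound 3 (within the scatter)), so this exchange does not separate compound 2 from compound 3. The comparison with compound 1 adds a second aryl example: 4-chlorophenyl in place of methyl on the carbonyl carbon also gives a large step beyond the scatter (a number 47.1 percentage points lower from compound 1 to compound 3 (beyond the scatter)), so the loss seen with 4-cyanophenyl (a number 49.5 percentage points lower from compound 1 to compound 2 (beyond the scatter)) does not depend on the cyano group alone, at least across these three compounds. No measured information here explains the size of either step or the similar readings of compound 2 and compound 3.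

The compounds shown leave open how an amine, a carboxylic acid or a methoxy group on that same aromatic carbon would read in this assay. Also open, from the compounds shown here alone, is how much of the loss goes with the ring itself, a question that an unsubstituted phenyl, an ethyl group or a longer chain on the carbonyl carbon could help to settle.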